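The source may hold more compounds than are shown below. What is called first, only, known or untested is meant among the compounds shown, and "the series" means these compounds.

Measured so far:
- compound 1 `O=C(COc1cccc2ccccc12)N/N=C/c1ccccc1Br`: 4.81
- compound 2 `C/C(=N\NC(=O)COc1cccc2ccccc12)c1ccccc1Br`: 4.44
- compound 3 `O=C(COc1cccc2ccccc12)N/N=C/c1ccccc1[N+](=O)[O-]`: 3.97

In a physicochemical assay for lipophilicity, measured as octanol-water partition (on this read-out higher numbers stand for higher lipophilicity and lower numbers for lower lipophilicity), compound 1 gives 4.81, the highest of the three numbers. Its nearest neighbour is compound 2 with 4.44, and the furthest is compound 3 with 3.97; both lie beyond the scatter of compound 1.

The unmeasured compound 4 `O=C(COc1cccc2ccccc12)N/N=C/c1ccc(F)cc1` differs from compound 1 in one place: 4-fluorophenyl in place of 2-bromophenyl on a carbon with a double bond to nitrogen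

For the measured compounds named here, only one measured step changes a single group on the same ring. From compound 1 to compound 3 the bromo group is swapped for a nitro group on an aromatic carbon, and this gives a number 0.84 log units lower from compound 1 to compound 3 (beyond the scatter), a modest drop. Going by the values given here, no measured step replaces bromo with fluoro, and no measured step moves a group from one ring position to another, so the expectation rests on that one step and on the swap of halogen alone.

For compound 4 a step in this assay of about a number 0.71 log units lower from compound 1 to compound 4 (beyond the scatter) is expected, downward and beyond the scatter but not larger than the drop to compound 3. The estimate for compound 4 is 4.1, with a range from 3.7 to 4.5.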

Compound 4, partition coefficient: 4.16
The estimate for compound 4 lay 0.06 log units below the measured number; the measured number falls inside the stated range.
By their numbers in this assay, from the lowest: compounds 3, 4 and 2 (each within the scatter of the next, the first and the last beyond it); then compound 1.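

In this assay, putting 4-fluorophenyl in place of 2-bromophenyl on the carbon with a double bond to nitrogen gives a number 0.65 log units lower from compound 1 to compound 4 (beyond the scatter), so a second replacement of the 2-bromophenyl group also ends beyond the scatter from compound 1, and this time the new group still carries a halogen. Compound 4 and compound 3 sit within the scatter of each other, even though they carry different groups, but this single step changes two things at once: fluorine enters for bromine, and the name of the group shows that the halogen's ring position changes too. None of the measurements shown accounts for the drop.

Whether the lower number follows the change of halogen or the change of ring position stays open, since no compound shown changes one without the other. On these data alone, how a ring carrying an amine, a carboxylic acid or a methoxy group at this place would read in this assay also stays open.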